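A few compounds are considered here, and "the series" means these few. Any claim that something is new, unique, unknown or untested is made for them only; others in the source may bear on it.

Measured so far:
- compound 1 `O=S(=O)(c1cccc(F)c1)c1cnc2c(F)cccc2c1-c1ccc(Cl)cc1`: 0.62 mL/min
- compound 2 `O=S(=O)(c1cccc(F)c1)c1cnc2c(F)cccc2c1-c1cccc(Cl)c1`: 0.56 mL/min
- compound 3 `COc1ccc(-c2c(S(=O)(=O)c3cccc(F)c3)cnc3c(F)cccc23)cc1`: 2.48 mL/min

These three compounds share one core and differ only in the aryl group attached to it. In an ADME assay on microsomes from liver (Homo sapiens) for metabolic stability, tested at 2.5 uM (a lower number here means slower removal, a higher number faster removal of the compound), compound 1 gives 0.62 mL/min, the second highest of the three numbers; compound 2 lies closest, and the step of a 1.1-fold lower number from compound 1 to compound 2 (0.04 log units; within the scatter) stays within the scatter. Compound 3 stands furthest away, with a 4.0-fold higher number from compound 1 to compound 3 (0.60 log units; beyond the scatter), a modest rise.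

Compound 4 `N#Cc1cccc(S(=O)(=O)c2cnc3c(F)cccc3c2-c2ccc(Cl)cc2)c1` changes a different part of the molecule: cyano in place of fluoro on an aromatic carbon. Among the measured compounds shown here, none of the measured steps touches this position; the steps from compound 1 to compound 2 and from compound 1 to compound 3 all alter the other aryl ring, and the step from compound 2 to compound 3, a 4.4-fold higher number from compound 2 to compound 3 (0.65 log units; beyond the scatter), likewise. There is thus no measured comparison to lean on, and the expectation for compound 4 in this assay is a step of about a 1.1-fold higher number from compound 1 to compound 4 (0.05 log units; within the scatter), not beyond the scatter. The estimate for compound 4 is therefore 0.7 mL/min, within a range from 0.35 mL/min to 1.4 mL/min.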

Compound 4, intrinsic clearance in a liver preparation (reported as CLH), per the amount of preparation that the assay uses: 0.08 mL/min
For compound 4 the middle estimate is 8.8-fold (0.94 log units) above the measured one, outside the stated range (below it).
By their numbers in this assay, from the lowest: compound 4; then compounds 2 and 1 (each within the scatter of the next); then compound 3.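

Among the compounds shown here, the ring carrying the fluoro, which no earlier step touched, turns out to count in this assay: replacing 3-fluorophenyl with 3-cyanophenyl gives a 7.8-fold lower number from compound 1 to compound 4 (0.89 log units; beyond the scatter), a step beyond the scatter. Until now, only changes on the other aryl ring had been seen to move the number, and the steps beyond the scatter there, those to compound 3, were rises, so this is the first step shown that lowers it beyond the scatter. Nothing measured here explains this drop.

Going by these compounds, it remains open whether the step belongs to the cyano group in particular or would also appear with another group on this aromatic carbon, such as an amine or a carboxylic acid. On these data alone, whether the same swap would give a similar step on compound 2 or compound 3 also remains unknown.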